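Compound 2 to compound 4: acetamido in place of nitro

The source may report more compounds than this note shows. Statements on the series, on what has been measured and on what is new or still open speak of the compounds shown alone.

In an ADME assay on HeLa cells (Homo sapiens) for cytotoxicity, read by crystal violet staining, with a stated time of 72 h (on this read-out higher numbers stand for lower toxicity in this test and lower numbers for higher toxicity in this test), compound 1 `CCOC(=O)c1cc(CCCOc2ccc(-c3noc(C(F)(F)F)n3)cc2[N+](=O)[O-])on1` gives > 100000 nM, which is a limit of the assay and not a number. Compound 2 `CN(C)C(=O)c1cc(CCCOc2ccc(-c3noc(C(F)(F)F)n3)cc2[N+](=O)[O-])on1` gives 22500 nM and compound 3 `COc1cc(-c2noc(C(F)(F)F)n2)cc([N+](=O)[O-])c1OCCCc1cc(C(=O)N(C)C)no1` gives 25600 nM. For the measured compounds named here, these are the only two true numbers, and they lie within the scatter of each other.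

Compound 4 `CC(=O)Nc1cc(-c2noc(C(F)(F)F)n2)ccc1OCCCc1cc(C(=O)N(C)C)no1` differs from compound 2 by acetamido in place of nitro on an aromatic carbon, ortho to a large group: acetamido in place of nitro on an aromatic carbon. Going by the values given here, no measured step covers this replacement, so the guidance is indirect. Dimethylamino in place of ethoxy on a carbonyl carbon gives an at least 4.4-fold lower number from compound 1 to compound 2 (0.64 log units; beyond the scatter), a change beyond the scatter but at a different site. Methoxy in place of hydrogen on an aromatic carbon gives a 1.1-fold higher number from compound 2 to compound 3 (0.06 log units; within the scatter), which stays within the scatter. Going by that step to compound 3, the expected step in this assay is small, with none beyond the scatter, and is estimated as a 1.3-fold higher number from compound 2 to compound 4 (0.12 log units; within the scatter). For compound 4 the estimated value is 30000 nM, with an expected range of 10000 nM to 90000 nM.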

Compound 4, half-maximal cytotoxic concentration: > 100000 nM
Compound 4 gave a limit, no number (the forecaster's own chance of this, stated with the estimate: 15%); at least 3.3-fold (0.52 log units) between middle value and limit.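

In this assay, acetamido in place of nitro on the aromatic carbon ortho to a large group gives an at least 4.4-fold higher number from compound 2 to compound 4 (0.64 log units; beyond the scatter), so the number responds to this position and not only to the carbonyl site. Compound 4 gives > 100000 nM, which is a limit of the assay and not a number. The step is therefore a bound only, because it rests on a limit: the limit of > 100000 nM in this assay, at which 2 of the 4 values shown sit.

The compounds shown do not separate the loss of nitro from the entry of acetamido, and an amine or a plain hydrogen at this position would tell the two apart. Also open, as far as these compounds go, is how a carboxylic acid at the carbonyl site, or a longer chain in the linker, would read alongside acetamido.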